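Swapping the amide aryl group on a weak phenyl analogue

The source may hold more compounds than are shown below. What is called first, only, known or untested is meant among the compounds shown, and "the series" means these compounds.

Compound 1 `Cc1ccc(F)cc1NC(=O)CN1CCN(c2nnc(Cc3ccccc3)c3ccccc23)CC1` gives 171000 nM in a functional assay on HT-29 cells (Homo sapiens) for cytotoxicity, read by MTT assay, with a stated time of 72 h; on this read-out lower numbers stand for stronger inhibition and higher numbers for weaker inhibition.
Compound 2 `Cc1ccc(F)cc1NC(=O)CN1CCN(c2nnc(Cc3ccncc3)c3ccccc23)CC1` gives 470 nM in this assay.
Compound 3 `O=C(CN1CCN(c2nnc(Cc3ccncc3)c3ccccc23)CC1)Nc1cc(C(F)(F)F)ccc1Cl` gives 4810 nM in this assay.

Compound 1 stands at the highest number of the three, and its distance from both other compounds lies beyond the scatter. The step from compound 1 to compound 2 is a 360-fold lower number from compound 1 to compound 2 (2.56 log units; beyond the scatter), the step from compound 2 to compound 3 is a 10-fold higher number from compound 2 to compound 3 (1.01 log units; beyond the scatter).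

Compound 4 `O=C(CN1CCN(c2nnc(Cc3ccccc3)c3ccccc23)CC1)Nc1cccc(Br)c1` differs from compound 1 in one place: 3-bromophenyl in place of 5-fluoro-2-methylphenyl on an amide-type nitrogen. Among the measured compounds shown here, of the measured steps only the one from compound 2 to compound 3 bears on this, as it also exchanges the group on the amide-type nitrogen, though on the pyridin-4-yl core and with a different entering group; there it was large and raised the number. No measurement with 3-bromophenyl exists here. The account therefore expects the number of compound 4 to stay high, with a 1.5-fold higher number from compound 1 to compound 4 (0.16 log units; within the scatter) as the estimated step. For compound 4 the estimate in this assay is 250000 nM, between 60000 nM and 900000 nM.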

Compound 4, half-maximal inhibitory concentration: 13400 nM
Compound 4: the middle estimate sits 19-fold (1.27 log units) above what was measured, outside the stated range (below it).
By their numbers in this assay, from the lowest: compound 2; then compound 3; then compound 4; then compound 1.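

Exchanging 5-fluoro-2-methylphenyl for 3-bromophenyl on the amide-type nitrogen in this assay gives a 13-fold lower number from compound 1 to compound 4 (1.11 log units; beyond the scatter), so this position also moves the number strongly in a compound that carries phenyl rather than pyridin-4-yl on the saturated chain carbon. The earlier exchange at this position, in the pyridin-4-yl pair, raised the number, whereas this one lowers it; the two steps differ in both the entering group and the rest of the molecule, so the direction of change is not fixed for the position as a whole. No measurement at hand gives a reason for the drop.

The compounds shown leave open whether 3-bromophenyl would also lower the number when paired with pyridin-4-yl. They also leave open how 3-chlorophenyl or 3-methoxyphenyl would compare on the same amide-type nitrogen.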